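Swapping Fluoro for Nitro: Effect on HeLa Cell Growth

The source may hold more compounds than are shown below. What is called first, only, known or untested is meant among the compounds shown, and "the series" means these compounds.

Three compounds have been measured in a functional assay on HeLa cells (Homo sapiens) for antiproliferative activity, read by MTT assay, with a stated time of 6 days; a higher number here means a weaker inhibitor, a lower number a stronger inhibitor:
compound 1 `O=C1C=C[C@@H](OCc2ccccc2)[C@@H]([C@@H](COC(=O)/C=C/c2ccc(F)cc2)OCc2ccccc2)O1`, 7310 nM;
compound 2 `O=C1C=C[C@@H](OCc2ccccc2)[C@@H]([C@@H](COC(=O)/C=C/c2ccc([N+](=O)[O-])cc2)OCc2ccccc2)O1`, 2650 nM;
compound 3 `CC(=O)O[C@@H]1C=CC(=O)O[C@@H]1[C@@H](COC(=O)/C=C/c1ccc(F)cc1)OC(C)=O`, 1680 nM.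

Compound 1 and compound 2 share one core and differ only by nitro in place of fluoro on an aromatic carbon; this change gave a 2.8-fold lower number from compound 1 to compound 2 (0.44 log units; beyond the scatter). Compound 3 carries a different core, and how the two cores differ is not broken down here. Compound 4 `CC(=O)O[C@@H]1C=CC(=O)O[C@@H]1[C@@H](COC(=O)/C=C/c1ccc([N+](=O)[O-])cc1)OC(C)=O`, not yet measured, relates to compound 3 by the same change, (nitro in place of fluoro on an aromatic carbon), at a place described in the same words as before. Because compound 1 and compound 2 gave a 2.8-fold lower number from compound 1 to compound 2 (0.44 log units; beyond the scatter), compound 4 is expected to show a step of similar size on its own core, a 2.7-fold lower number from compound 3 to compound 4 (0.43 log units; beyond the scatter). Compound 4 is therefore estimated at 620 nM in this assay, with a likely range from 250 nM to 1500 nM.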

Compound 4, half-maximal inhibitory concentration: 1840 nM
Compound 4: middle estimate off by 3.0-fold (0.47 log units), on the low side, outside the stated range (above it).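

In this assay, nitro in place of fluoro on the core of compound 3 gave a 1.1-fold higher number from compound 3 to compound 4 (0.04 log units; within the scatter), so these two compounds cannot be told apart. The step seen on the first core therefore did not carry over to the second: the same change on two cores in this assay, a 2.8-fold lower number (0.44 log units; beyond the scatter) from compound 1 to compound 2 and a 1.1-fold higher number (0.04 log units; within the scatter) from compound 3 to compound 4, 3.0-fold (0.48 log units) apart, beyond the scatter of two such steps. This shows that a step measured on one core cannot be assumed for the other in this series, but it does not show which part of the cores accounts for the gap.

Among the compounds shown here, with only two pairs, it remains open how the change would behave on any further core. As far as these compounds go, it is also open whether an amine or a carboxylic acid in the same place would give matching steps on these two cores.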